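The compounds below may be only part of what the source reports. "The series", "measured", "known", "first", "only" and "open" are said of these compounds alone.

Working notes on the series.

Compound 1 `CSCC[C@H](NC(=O)c1ccc(NCc2cncn2Cc2cccc(C)c2)cc1-c1ccccc1)C(=O)O`, compound 2 `CSCC[C@H](NC(=O)c1ccc(NCc2cncn2Cc2ccc(C)cc2)cc1-c1ccccc1)C(=O)O` and compound 3 `CSCC[C@H](NC(=O)c1ccc(NCc2cncn2Cc2ccc(C#N)cc2)cc1-c1ccccc1)C(=O)O` share one core and differ only in the substituted phenyl on the saturated chain carbon bound to the aromatic nitrogen. In a functional assay on NIH3T3 cells (Mus musculus) (a higher number here means that more compound is needed for the effect, a lower number that less compound is needed), compound 1 gives > 10 uM, which is a limit of the assay and not a number. In this assay compound 2 gives > 10 uM, again a limit. In this assay compound 3 gives > 10 uM, also a limit. The steps a step that the two limits leave unreadable from compound 1 to compound 2, a step that the two limits leave unreadable from compound 1 to compound 3 and a step that the two limits leave unreadable from compound 2 to compound 3 are therefore all unreadable, since (the limit of > 10 uM in this assay, at which 3 of the 3 values shown sit).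

Compound 4 `CSCC[C@H](NC(=O)c1ccc(NCc2cncn2Cc2cccc(Cl)c2)cc1-c1ccccc1)C(=O)O` is not yet measured. Its difference from compound 3 is 3-chlorophenyl in place of 4-cyanophenyl on a saturated chain carbon bound to an aromatic nitrogen. The measured steps bear on it only in that three phenyl variations at this place all stayed at the limit; no step size can be read from them. The expectation for compound 4 is accordingly that it stays near that limit, and the step that the limit leaves unreadable from compound 3 to compound 4 is expected to be small. For compound 4 the estimate in this assay is 20 uM, within 5 uM to 100 uM.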

Compound 4, concentration for half-maximal effect: > 10 uM
Compound 4: only a limit was reported (the forecaster's own chance of this, stated with the estimate: 80%); the middle value lies beyond the limit too.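

In this assay compound 4 gives > 10 uM, again a limit and not a number. No step between compound 4 and compound 1, compound 2 or compound 3 can be read: the limit of > 10 uM in this assay, at which 4 of the 4 values shown sit.

The compounds shown leave open how any of these substituted phenyl groups changes the concentration needed in this assay.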